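Solubility step from compound 3 to compound 4

The source may report more compounds than this note shows. Statements on the series, on what has been measured and on what is new or still open speak of the compounds shown alone.

In a physicochemical assay for solubility, read by LC-MS, in phosphate buffer, with a stated time of 24 h, at pH 7.4 (a lower number here means a less soluble compound, a higher number a more soluble compound), compound 3 `CN(C)C(=O)c1cc(-c2cnc(NCc3c(F)ccc4c3CCO4)c3cn[nH]c(=O)c23)n(C)n1` gives 3000 nM, level with compound 1 `Cc1nc(CO)ccc1-c1cnc(NCc2c(F)ccc3c2CCO3)c2cn[nH]c(=O)c12` at 3000 nM. Compound 2 `CC(=O)N1CCC(c2cnc(NCc3c(F)ccc4c3CCO4)c3cn[nH]c(=O)c23)CC1` gives < 2000 nM, which is a limit of the assay and not a number.

Compound 4 `CNC(=O)c1ncc(-c2cnc(NCc3c(F)ccc4c3CCO4)c3cn[nH]c(=O)c23)n1C` has not been measured. It carries 1-methyl-2-(methylcarbamoyl)-1H-imidazol-5-yl in place of 3-(dimethylcarbamoyl)-1-methyl-1H-pyrazol-5-yl on an aromatic carbon.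

Three measured exchanges of a group at this same place bear on the change: no change at the digits printed from compound 1 to compound 3 (within the scatter), an at least 1.5-fold lower number from compound 1 to compound 2 (0.17 log units; that floor lies within the scatter) and an at least 1.5-fold higher number from compound 2 to compound 3 (0.17 log units; that floor lies within the scatter). None of them shows a size beyond the scatter, although the two steps involving the limit give only floors. For the measured compounds named here, no measured step tests this exact exchange.

In this assay, the estimated change is no change at the digits printed from compound 3 to compound 4 (within the scatter), and no step beyond the scatter is expected in either direction. For compound 4 the expected value is 3000 nM, with an estimated range of 1500 nM to 6000 nM.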

Compound 4, solubility: 5000 nM
Beside the measured number, compound 4's estimate is 1.7-fold (0.22 log units) below it; the range from low to high includes it.
By their numbers in this assay, from the lowest: compounds 1, 3 and 4 (each within the scatter of the next). At a limit, below all of these: compound 2.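

In this assay, this position gives a 1.7-fold higher number from compound 3 to compound 4 (0.22 log units; within the scatter) and a 1.7-fold higher number from compound 1 to compound 4 (0.22 log units; within the scatter), so 1-methyl-2-(methylcarbamoyl)-1H-imidazol-5-yl cannot be ordered against either aromatic group it is compared with here. For the compounds shown here, the new result also gives the first step at this position with a floor beyond the scatter: an at least 2.5-fold higher number from compound 2 to compound 4 (0.39 log units; beyond the scatter). That step gives a floor and not a full size, and compound 2 stands at a limit of the assay, not a number: the limit of < 2000 nM in this assay, at which 1 of the 4 values shown sits.

The exchange of 3-(dimethylcarbamoyl)-1-methyl-1H-pyrazol-5-yl for 1-methyl-2-(methylcarbamoyl)-1H-imidazol-5-yl alters the ring and the amide together, and the compounds shown do not separate the two. Going by these compounds, whether an amine or a carboxylic acid at this place would move the number beyond the scatter from compound 4 remains open.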